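The compounds below may be only part of what the source reports. "The series", "measured", "known", "first", "only" and "open" are said of these compounds alone.

Notes on the benzamide series in a functional assay on A-375 cells (Homo sapiens) for antiproliferative activity, read by CCK-8 assay, with a stated time of 72 h, tested at 8 uM; on this read-out higher numbers stand for a stronger effect at the one concentration tested and lower numbers for a weaker effect. Compound 1 `CN(Cc1cccnc1)C(=S)SCc1ccc(C(=O)Nc2ccccc2N)cc1` gives 83.8% in this assay. Compound 3 `Nc1ccccc1NC(=O)c1ccc(CSC(=S)N2CCN(Cc3cccnc3)CC2)cc1` gives 89.2%. Compound 2 `COc1ccc(N2CCN(C(=S)SCc3ccc(C(=O)Nc4ccccc4N)cc3)CC2)cc1` gives 35.9%, the lowest of the three numbers; compound 1 lies nearest to it and compound 3 furthest, and both gaps lie beyond the scatter. Compound 4 `CN1CCN(C(=S)SCc2ccc(C(=O)Nc3ccccc3N)cc2)CC1` has not yet been run in this assay. It differs from compound 2 in one place: methyl in place of 4-methoxyphenyl on an amine nitrogen in a ring. Among the compounds with values here, the one measured step that touches the same position is the one from compound 2 to compound 3, where the 4-methoxyphenyl left and (pyridin-3-yl)methyl entered, giving a number 53.3 percentage points higher from compound 2 to compound 3 (beyond the scatter). Within the data shown here, nothing measured shows a methyl at this position, so the size of the step in this assay cannot be read off directly; the one comparison at hand has the 4-methoxyphenyl leaving and the number rising sharply, which points to an increase for compound 4 as well, though its size is uncertain and may well fall short of what compound 3 showed. Compound 4 is therefore expected to give 60%, with a range of 35% to 85%. This estimate means an expected step of a number 24.1 percentage points higher from compound 2 to compound 4 (beyond the scatter).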

Compound 4, a percentage reported as inhibition, at one concentration (the size of the read-out at that concentration, not a potency): 91.6%
Beside the measured number, compound 4's estimate is 31.6 percentage points below it; measured number above the stated range.
By their numbers in this assay, from the lowest: compound 2; then compounds 1, 3 and 4 (each within the scatter of the next).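

In this assay, the methyl on the amine nitrogen in the ring gives a number 55.7 percentage points higher from compound 2 to compound 4 (beyond the scatter), and it matches the much larger (pyridin-3-yl)methyl, with a number 2.4 percentage points higher from compound 3 to compound 4 (within the scatter). The earlier step from compound 2 to compound 3 could not separate the loss of the 4-methoxyphenyl from the arrival of the pyridin-3-yl; this result shows that no pyridin-3-yl is needed at this position for a high number, and among compounds 2, 3 and 4 only the 4-methoxyphenyl goes with a low one. The 4-methylpiperazin-1-yl also holds up against the open methyl((pyridin-3-yl)methyl)amino group on the thiocarbonyl carbon, with a number 7.8 percentage points higher from compound 1 to compound 4 (within the scatter), so compounds 1, 3 and 4 cannot be told apart at this one concentration.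

Nothing at hand explains why compound 2 stands apart from the others. The compounds shown leave open whether the low number follows any aromatic ring placed directly on this nitrogen or the methoxy group in particular, which an unsubstituted phenyl would address, and whether a benzyl or a longer chain such as butyl keeps the number as high as the methyl does.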